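The compounds below may be only part of what the source reports. "The series", "measured", "known", "first", "only" and "open" are said of these compounds alone.

Compound 3 `COc1ccc(-c2cc(C(=O)Nc3ccc(Oc4ccnc5cc(OCCCN6CCCCC6)c(OC)cc45)c(F)c3)c3cc(F)ccc3n2)cc1` gives 240 nM in a functional assay on NCI-H460 cells (Homo sapiens) for cytotoxicity, read by MTT assay, with a stated time of 72 h; on this read-out higher numbers stand for weaker inhibition and lower numbers for stronger inhibition. Going by the values given here, it stands second highest of the three numbers so far: compound 2 `COc1cccc(-c2cc(C(=O)Nc3ccc(Oc4ccnc5cc(OCCCN6CCCCC6)c(OC)cc45)c(F)c3)c3cc(F)ccc3n2)c1` gives 1000 nM, and compound 1 `COc1cc2c(Oc3ccc(NC(=O)c4cc(-c5ccccc5)nc5ccc(F)cc45)cc3F)ccnc2cc1OCCCN1CCCCC1` gives 32 nM. The measured steps are a 31-fold higher number from compound 1 to compound 2 (1.49 log units; beyond the scatter), a 7.5-fold higher number from compound 1 to compound 3 (0.88 log units; beyond the scatter) and a 4.2-fold lower number from compound 2 to compound 3 (0.62 log units; beyond the scatter). Compound 4 `COc1cc2c(Oc3ccc(NC(=O)c4cc(-c5ccc(Cl)cc5Cl)nc5ccc(F)cc45)cc3F)ccnc2cc1OCCCN1CCCCC1` is not yet measured; it differs from compound 3 by 2,4-dichlorophenyl in place of 4-methoxyphenyl on an aromatic carbon. Among the compounds with values here, no measured step puts chlorine on this ring, so the three steps bear on the change only indirectly: both steps from compound 1 show that a methoxy on the phenyl raised the number, and the step from compound 2 to compound 3 shows that which methoxyphenyl is present changes the number. A ring carrying two chlorines is a new case, and a number between those of compound 1 and compound 3 is expected, with wide uncertainty. Compound 4 is estimated at 120 nM, within 30 nM to 500 nM. The expected step of a 2.0-fold lower number from compound 3 to compound 4 (0.30 log units; within the scatter) is therefore small, within the scatter.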

Compound 4, half-maximal inhibitory concentration: 310 nM
For compound 4 the middle estimate is 2.6-fold (0.41 log units) below the measured one; the range from low to high includes it.
By their numbers in this assay, from the lowest: compound 1; then compounds 3 and 4 (each within the scatter of the next); then compound 2.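

In this assay, 2,4-dichlorophenyl and 4-methoxyphenyl on the aromatic carbon next to the ring nitrogen are not told apart, with a 1.3-fold higher number from compound 3 to compound 4 (0.11 log units; within the scatter) and so no separation between a ring bearing two chlorines and one bearing a methoxy. Methoxy is therefore not the only substitution shown to give a higher number than plain phenyl, as a 9.7-fold higher number from compound 1 to compound 4 (0.99 log units; beyond the scatter) extends that result to a chlorinated ring, while a 3.2-fold lower number from compound 2 to compound 4 (0.51 log units; beyond the scatter) keeps 2,4-dichlorophenyl apart from 3-methoxyphenyl. Nothing measured on these compounds gives a reason for these steps.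

From the compounds shown here alone, whether a single chlorine on the phenyl gives the same number as two remains open. Also open, going by these compounds, is how this position responds to a phenyl carrying an amine or a carboxylic acid, or to a saturated ring such as cyclohexyl in place of the phenyl.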